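The compounds below may be only part of what the source reports. "The series", "measured", "known", "first", "only" and "open" are said of these compounds alone.

Measured in a functional assay on ECa-109 cells (Homo sapiens) for antiproliferative activity, read by MTT assay, with a stated time of 72 h; a higher number here means a weaker inhibitor, a lower number a stronger inhibitor:
- compound 1 `CCCSc1nc(N/N=C(\C)c2ccccc2O)c2nnn(Cc3ccc(Cl)cc3)c2n1`: 11200 nM
- compound 2 `CCCSc1nc(N/N=C/c2ccc(C)cc2)c2nnn(Cc3ccccc3)c2n1`: > 64000 nM, a limit of the assay rather than a number
- compound 3 `CCCSc1nc(N/N=C/c2cccs2)c2nnn(Cc3ccccc3)c2n1`: > 64000 nM, again a limit rather than a number

Compound 1 therefore stands as the only one of the three with a measured number; the other two sit at the limit of > 64000 nM in this assay, at which 2 of the 3 values shown sit. For the measured compounds named here, the single step between measured compounds, a step that the two limits leave unreadable from compound 2 to compound 3, changes a different part of the molecule and cannot be sized, so it says nothing about the change considered here.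

Compound 4 `CCCSc1nc(N/N=C(\C)c2ccccc2O)c2nnn(Cc3ccco3)c2n1` differs from compound 1 by furan-2-yl in place of 4-chlorophenyl on a saturated chain carbon bound to an aromatic nitrogen. Going by the values given here, no measured step touches this position, so the expectation rests on compound 1 alone, with wide uncertainty in both directions and a real chance that the assay again reports only a limit. The expected step, a 1.3-fold higher number from compound 1 to compound 4 (0.13 log units; within the scatter), is estimated to lie within the usual scatter. Compound 4 is thus expected to give 15000 nM in this assay, between 4000 nM and 60000 nM.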

Compound 4, half-maximal inhibitory concentration: 5760 nM
Estimate against measurement, compound 4: 2.6-fold (0.42 log units) above; low and high end bracket the measured number.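

In this assay, for the compounds shown here, this pair gives the only readable step at the group on a saturated chain carbon bound to an aromatic nitrogen: a 1.9-fold lower number from compound 1 to compound 4 (0.29 log units; within the scatter). Exchanging 4-chlorophenyl, a six-membered carbon ring bearing chlorine, for furan-2-yl, a five-membered ring with one hetero atom and one hydrogen-bond acceptor, therefore gives no readable difference in this pair, and both compound 1 and compound 4 give a measured number. Compounds 2 and 3 remain the ones that give only a limit: the limit of > 64000 nM in this assay, at which 2 of the 4 values shown sit.

From the compounds shown here alone, whether a longer alkyl chain, or a ring carrying an amine or a carboxylic acid, at this position would shift the number beyond the scatter remains open. So does whether the same exchange would read alike with other parts of compound 1 changed.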